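A few compounds are considered here, and "the series" means these few. Any claim that something is new, unique, unknown or untested is made for them only; others in the source may bear on it.

Three compounds have been measured in a functional assay on A-375 cells (Homo sapiens) for cytotoxicity, read by MTT assay, with a stated time of 48 h; a higher number here means a weaker inhibitor, a lower number a stronger inhibitor:

Compound 1, `CC1(C)S[C@@H]2/C(=C\C(=O)c3ccco3)C(=O)N2[C@H]1C(=O)OC(c1ccccc1)c1ccccc1`: 26000 nM
Compound 2, `CCOC(=O)/C=C1/C(=O)N2[C@@H]1SC(C)(C)[C@@H]2C(=O)OC(c1ccccc1)c1ccccc1`: 7000 nM
Compound 3, `CC1(C)S[C@@H]2/C(=C\C(=O)OCc3ccccc3)C(=O)N2[C@H]1C(=O)OC(c1ccccc1)c1ccccc1`: 7100 nM

Compound 3 stands second highest of the three numbers: against compound 2 the step is a 1.0-fold higher number from compound 2 to compound 3 (0.01 log units; within the scatter), within the scatter, while from compound 1 it is a 3.7-fold lower number from compound 1 to compound 3 (0.56 log units; beyond the scatter). Compound 4, `CC1(C)S[C@@H]2/C(=C\C(=O)c3ccccc3)C(=O)N2[C@H]1C(=O)OC(c1ccccc1)c1ccccc1`, differs from compound 3 by phenyl in place of benzyloxy on a carbonyl carbon. For the measured compounds named here, the steps that bear on it are a 3.7-fold lower number from compound 1 to compound 2 (0.57 log units; beyond the scatter) and a 3.7-fold lower number from compound 1 to compound 3 (0.56 log units; beyond the scatter), where ethoxy or benzyloxy replaced furan-2-yl on the carbonyl carbon and the number fell. The present change runs the other way, phenyl in place of benzyloxy on that carbonyl carbon, so a rise of similar size is expected, a 2.8-fold higher number from compound 3 to compound 4 (0.45 log units; beyond the scatter). Compound 4 is therefore estimated at 20000 nM, with a range of 6000 nM to 60000 nM.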

Compound 4, half-maximal inhibitory concentration: 22800 nM
Estimate against measurement, compound 4: 1.1-fold (0.06 log units) below, and the stated range covers the measured number.
By their numbers in this assay, from the lowest: compounds 2 and 3 (each within the scatter of the next); then compounds 4 and 1 (each within the scatter of the next).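

In this assay the group on this carbonyl carbon now falls into two sets: compound 4 with its phenyl sits with the furan-2-yl compound, a 1.1-fold lower number from compound 1 to compound 4 (0.06 log units; within the scatter), while replacing either ester group with phenyl gives a 3.2-fold higher number from compound 3 to compound 4 (0.51 log units; beyond the scatter) and a 3.3-fold higher number from compound 2 to compound 4 (0.51 log units; beyond the scatter). Benzyloxy and phenyl each hold a six-membered aromatic ring, so the presence of that ring alone does not track the number across this pair. No measured evidence here accounts for the difference. The compounds shown leave open how an amide or a methyl ketone would read at this carbonyl carbon.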